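The compounds below may be only part of what the source reports. "The series", "measured", "known", "first", "only" and "open" are said of these compounds alone.

In a functional assay on MCF7 cells (Homo sapiens) for inhibition, read by MTT assay, with a stated time of 72 h (a higher number here means a weaker inhibitor, a lower number a stronger inhibitor), compound 1 `Nc1nc2cc(-c3nn(CCCCC(=O)NO)c4ncnc(N)c34)ccc2o1` gives 14000 nM. Among the compounds with values here, in the same assay, compound 2 `Nc1nc2cc(-c3nn(CCCCCC(=O)NO)c4ncnc(N)c34)ccc2o1` gives 12400 nM, and these two values lie within the scatter of each other, so compound 2 stands level with the only other measured compound. Compound 3 `Nc1nc2cc(-c3nn(CC(=O)NO)c4ncnc(N)c34)ccc2o1` has not yet been measured. It carries hydroxycarbamoyl in place of 4-(hydroxycarbamoyl)butyl on a saturated chain carbon bound to an aromatic nitrogen. Within the data shown here, only one measured step bears on this change: a 1.1-fold lower number from compound 1 to compound 2 (0.05 log units; within the scatter). Among the measured compounds shown here, the change to compound 3 removes more of the chain than separates compound 1 and compound 2, and no compound with so short a chain has a measured value, so that step is a weak guide. A moderate rise in the number in this assay is expected, with wide uncertainty, and the estimate amounts to a 2.0-fold higher number from compound 2 to compound 3 (0.30 log units; within the scatter). Compound 3 is estimated at 25000 nM, with an expected range of 9000 nM to 70000 nM.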

Compound 3, half-maximal inhibitory concentration: > 100000 nM
Compound 3: only a limit was reported; the forecaster's own chance of this, stated with the estimate: 25%; middle value at least 4.0-fold (0.60 log units) from the limit.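

In this assay compound 3 gives > 100000 nM, which is a limit of the assay and not a number. Chain length at this position does matter, although the earlier pair gave no sign of it: hydroxycarbamoyl in place of 4-(hydroxycarbamoyl)butyl gives an at least 8.0-fold higher number from compound 2 to compound 3 (0.90 log units; beyond the scatter), and hydroxycarbamoyl in place of 3-(hydroxycarbamoyl)propyl gives an at least 7.1-fold higher number from compound 1 to compound 3 (0.85 log units; beyond the scatter). Both steps are lower bounds, so their true size remains unknown: the limit of > 100000 nM in this assay, at which 1 of the 3 values shown sits.

The compounds shown leave open at which intermediate chain length the number begins to rise, and whether a longer chain than 4-(hydroxycarbamoyl)butyl's successor in compound 2 would lower it. They also do not tell how a carboxylic acid in place of the hydroxycarbamoyl end would read in this assay.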